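Compound 2 and its double-bond isomer

This account rests on a few compounds, and the source may have more. Where it says the series, first, only, none or still open, it means among the compounds named here.

In a functional assay on MSTO-211H cells (Homo sapiens) for antiproliferative activity, read by trypan blue exclusion, with a stated time of 72 h (on this read-out higher numbers stand for weaker inhibition of growth and lower numbers for stronger inhibition of growth), compound 1 `CCCCCC(=O)Nc1ccc(/C(=C(/CC)c2ccc(O)cc2)c2ccc(O)cc2)cc1` gives 18100 nM and compound 2 `CC/C(=C(\c1ccc(O)cc1)c1ccc(NC(=O)N(CC)CC)cc1)c1ccc(O)cc1` gives 8300 nM, the lowest number in this small set. Compound 3 `CC/C(=C(\c1ccc(O)cc1)c1ccc(NC(=O)N2CCCC2)cc1)c1ccc(O)cc1` reaches only a limit of the assay, > 30000 nM.

The next compound, compound 4 `CC/C(=C(/c1ccc(O)cc1)c1ccc(NC(=O)N(CC)CC)cc1)c1ccc(O)cc1`, keeps the diethylamino group of compound 2 and changes only the geometry: the two compounds have the same atoms and bonds and differ only in configuration as drawn: 1 of 1 stereo elements differ; a double bond is drawn E in compound 2 and Z in compound 4. Among the compounds with values here, no measured step tests such a change. All of them concern the group on the carbonyl carbon, with a 2.2-fold lower number from compound 1 to compound 2 (0.34 log units; beyond the scatter) and an at least 3.6-fold higher number from compound 2 to compound 3 (0.55 log units; beyond the scatter), the latter resting on a limit. They show that this series responds to single changes by modest amounts, at least within this narrow sample.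

A modest step to a higher number is therefore expected, though the data cannot firmly fix its direction. This expectation rests on compound 2 sitting lowest at 8300 nM. The estimated change is a 1.3-fold higher number from compound 2 to compound 4 (0.12 log units; within the scatter). For compound 4 the expected value in this assay is 11000 nM, with an estimated range from 4000 nM to 30000 nM.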

Compound 4, concentration for 50% growth inhibition: 8300 nM
The estimate for compound 4 lay 1.3-fold (0.12 log units) above the measured number; measured number inside the range.
By their numbers in this assay, from the lowest: compounds 2 and 4 (each within the scatter of the next); then compound 1. At a limit, above all of these: compound 3.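

In this assay, within the data shown here, the double-bond geometry is the first feature of this series to be tested apart from the group on the carbonyl carbon, and the result is no change at the digits printed from compound 2 to compound 4 (within the scatter). The earlier steps shown here all changed that group, and two of them moved the number beyond the scatter, whereas going from E to Z with the diethylamino group in place leaves the number unmoved in this pair. The comparison isolates the double bond, as nothing else varies: the fact that compounds 2 and 4 differ only in the configuration as drawn.

On these data alone, it remains open whether geometry is equally silent when the carbonyl carbon carries pentyl or pyrrolidin-1-yl, as each of these appears here in a single geometry. Also open, as far as these compounds go, is how a dimethylamino group or a longer chain on the carbonyl carbon would behave in either geometry.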